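From 3-chlorophenyl to 4-fluorophenyl on the carbonyl

A few compounds are considered here, and "the series" means these few. Any claim that something is new, unique, unknown or untested is made for them only; others in the source may bear on it.

Compound 1 `Cc1cccc(NNC(=O)c2ccc(NS(=O)(=O)c3cnc(O)nc3O)cc2)c1` gives > 20000 nM in a functional assay on MDA-MB-231 cells (Homo sapiens) for antiproliferative activity, read by MTT assay, with a stated time of 24 h (on this read-out higher numbers stand for weaker inhibition and lower numbers for stronger inhibition), and this value is a limit of the assay, not a number. Among the compounds with values here, compound 2 `O=C(NNC(=O)c1cccc(Cl)c1)c1ccc(NS(=O)(=O)c2cnc(O)nc2O)cc1` gives 4160 nM, the only true number so far. Within the data shown here, the one measured step, an at least 4.8-fold lower number from compound 1 to compound 2 (0.68 log units; beyond the scatter), puts (3-chlorophenyl)carbonyl in place of 3-methylphenyl on an amine nitrogen. Compound 3 `O=C(NNC(=O)c1ccc(NS(=O)(=O)c2cnc(O)nc2O)cc1)c1ccc(F)cc1` has 4-fluorophenyl in place of 3-chlorophenyl on a carbonyl carbon. Among the measured compounds shown here, the step of an at least 4.8-fold lower number from compound 1 to compound 2 (0.68 log units; beyond the scatter) changes more than the aromatic ring substituent and so bears only loosely on this swap, and no measured pair isolates it. A small change is therefore expected, within the scatter and leaning towards weaker inhibition, as a 1.4-fold higher number from compound 2 to compound 3 (0.16 log units; within the scatter) in this assay. For compound 3 the estimated value is 6000 nM, with an expected range of 2200 nM to 16000 nM.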

Compound 3, half-maximal inhibitory concentration: > 20000 nM
Compound 3: a limit, no number (the forecaster's own chance of this, stated with the estimate: 20%); middle value at least 3.3-fold (0.52 log units) away from the limit.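

In this assay this position on the carbonyl carbon proves sensitive, with an at least 4.8-fold higher number from compound 2 to compound 3 (0.68 log units; beyond the scatter) on exchanging 3-chlorophenyl for 4-fluorophenyl. For compound 3 the reading > 20000 nM is a limit of the assay and not a number. Within the three compounds, measurable inhibition therefore rests on one group at this position, 3-chlorophenyl, and compound 2 stands alone with a true number: the limit of > 20000 nM in this assay, at which 2 of the 3 values shown sit.

The step from compound 1 to compound 3 cannot be read, as both values are limits. Going by these compounds, the swap changes both the halogen and its place on the ring, so it remains open which of the two matters; 3-fluorophenyl and 4-chlorophenyl on the same carbonyl would separate them.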